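Swapping Chloro for Cyano on the Shared Core

This account rests on a few compounds, and the source may have more. Where it says the series, first, only, none or still open, it means among the compounds named here.

Of the compounds shown here, three of a shared core have been tested, and every one of them sits at the limit of the assay rather than at a number. Compound 1 `CCS(=O)(=O)Nc1ccc(NC(=O)c2ccc(C#N)cc2)cc1C` carries a 4-cyanophenyl, and in an ADME assay on HEK293 cells (Homo sapiens) for cytotoxicity, read by MTT assay, with a stated time of 48 h (a higher number here means a weaker inhibitor, a lower number a stronger inhibitor), compound 1 gives only a limit, > 250000 nM. Compound 2 `CS(=O)(=O)Nc1ccc(NC(=O)c2ccc(C#N)cc2)cc1Cl` also carries a 4-cyanophenyl, and in this assay compound 2 again gives a limit, > 250000 nM. Compound 3 `CCS(=O)(=O)Nc1ccc(NC(=O)c2ccc(Cl)cc2)cc1Cl` carries a 4-chlorophenyl instead, and in this assay compound 3 likewise gives a limit, > 250000 nM. So compound 3 stands exactly where the other two stand: at the limit, as summarised by the limit of > 250000 nM in this assay, at which 3 of the 3 values shown sit. Among the measured compounds shown here, no step between two measured compounds can be read from these three, since none of them differs from another in one place only. Compound 4 `CCS(=O)(=O)Nc1ccc(NC(=O)c2ccc(C#N)cc2)cc1Cl` is not yet measured; it arises from compound 3 by the change (cyano in place of chloro on an aromatic carbon). The step from compound 3 to compound 4 is expected to be a step that the limit leaves unreadable from compound 3 to compound 4, that is, none beyond the usual scatter, with compound 4 most likely reported again only as a limit. The estimate for compound 4 in this assay is 300000 nM, within a range from 150000 nM to 1000000 nM.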

Compound 4, half-maximal inhibitory concentration: > 250000 nM
Compound 4: only a limit was reported (the forecaster's own chance of this, stated with the estimate: 90%); the middle value is on the limit's open side.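

In this assay compound 4 again gives only a limit, > 250000 nM. No step can be read from compound 4 to compound 1, compound 2 or compound 3, because all four compounds end at the same limit: the limit of > 250000 nM in this assay, at which 4 of the 4 values shown sit.

Whether cyano in place of chloro, or any other change among these compounds, alters the read-out at all stays open.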